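A few compounds are considered here, and "the series" means these few. Any claim that something is new, unique, unknown or untested is made for them only; others in the source may bear on it.

Three compounds share one core and differ only in the chain hanging from it. Compound 1 `NC(=S)Nc1cccc(OCCCc2ccccc2)c1` reaches a limit of the assay, > 50000 nM, in an ADME assay on Ava5 cells (Homo sapiens) for cytotoxicity; on this read-out higher numbers stand for lower toxicity in this test and lower numbers for higher toxicity in this test. Compound 3 `NC(=S)Nc1cccc(OCCCCCOc2ccc(-c3ccccc3)cc2)c1` likewise reaches only a limit, > 50000 nM. For the measured compounds named here, compound 2 `NC(=S)Nc1cccc(OCCCCCCc2ccccc2)c1` is the one compound with an actual number in this assay, 28000 nM. Two of the three values shown sit at a limit (the limit of > 50000 nM in this assay, at which 2 of the 3 values shown sit). Compound 4 `NC(=S)Nc1cccc(OCCCCCOc2ccncc2)c1` has not yet been measured. It differs from compound 2 by (pyridin-4-yl)oxy in place of benzyl on a saturated chain carbon, five bonds along the chain from an oxygen on an aromatic ring. Going by the values given here, no measured pair shows what such a change does here, so the expected step is a 1.8-fold higher number from compound 2 to compound 4 (0.25 log units; within the scatter), a modest shift toward lower toxicity that need not exceed the scatter. Compound 4 is expected to give about 50000 nM, between 22000 nM and 110000 nM, and may again stop at a limit.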

Compound 4, half-maximal cytotoxic concentration: > 50000 nM
Compound 4 gave a limit, no number; the forecaster's own chance of this, stated with the estimate: 55%; the middle value sits exactly at the limit.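

In this assay, placing (pyridin-4-yl)oxy instead of benzyl on this saturated chain carbon gives an at least 1.7-fold higher number from compound 2 to compound 4 (0.25 log units; that floor lies within the scatter). For the compounds shown here, this is the first step that can be read at this position, and it shows no sign of higher toxicity from the change. Its true size cannot be read, as the result joins the others at the assay's ceiling: the limit of > 50000 nM in this assay, at which 3 of the 4 values shown sit.

The compounds shown leave open which part of the change counts, the added oxygen or the ring nitrogen, and phenoxy at this place would separate the two. As far as these compounds go, how an amine or a carboxylic acid would read here also stays open.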